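The compounds below may be only part of what the source reports. "The series", "measured", "known", "first", "only" and "open" are said of these compounds alone.

In an ADME assay on S9 fraction from liver (Rattus norvegicus) for metabolic stability, read by LC-MS, using NADPH, with a stated time of 30 min (on this read-out lower numbers stand for a less stable compound and higher numbers for a more stable compound), compound 1 `CCCCCCCCc1ccc(OCC(=O)Cn2nnnc2-c2ccccc2)cc1` gives 36% and compound 2 `CCCCCCCCc1ccc(OCC(=O)Cn2nnnc2-c2cccc(S(=O)(=O)N(C)C)c2)cc1` gives 24%, the lower of the two numbers. Within the data shown here, the only measured step is a number 12 percentage points lower from compound 1 to compound 2 (beyond the scatter), with dimethylsulfamoyl in place of hydrogen on an aromatic carbon. Compound 3 `CCCCCCCCc1ccc(OCC(=O)Cn2nnnc2-c2cccs2)cc1` changes compound 2 as follows: thiophen-2-yl in place of 3-(dimethylsulfamoyl)phenyl on an aromatic carbon. Like compound 1 at 36%, it carries no dimethylsulfamoyl, although no measured compound has thiophen-2-yl, so a modest rise of similar size is expected. The estimated change is a number 9 percentage points higher from compound 2 to compound 3 (within the scatter). For compound 3 the expected value is 33%, within an estimated range of 20% to 47%.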

Compound 3, percent of the compound remaining: 27%
Compound 3: middle estimate off by 6 percentage points, on the high side; low and high end bracket the measured number.
By their numbers in this assay, from the lowest: compounds 2, 3 and 1 (each within the scatter of the next, the first and the last beyond it).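

In this assay thiophen-2-yl brings a number 3 percentage points higher from compound 2 to compound 3 (within the scatter) and a number 9 percentage points lower from compound 1 to compound 3 (within the scatter). At this position, between two ring nitrogen atoms, the five-membered ring therefore cannot be told apart from either six-membered group, even though phenyl and 3-(dimethylsulfamoyl)phenyl differ from each other beyond the scatter. Nothing available explains these numbers. Still open, going by these compounds, is whether an amine or a carboxylic acid on the phenyl ring, or a furan-2-yl group at this position, would move the number clearly away from these three compounds.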